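Replacing bromo with amino in compound 2

The source may hold more compounds than are shown below. What is called first, only, known or untested is meant among the compounds shown, and "the series" means these compounds.

In a functional assay on MCF7 cells (Homo sapiens) for cytotoxicity, read by MTT assay, with a stated time of 6 days (a higher number here means that more compound is needed for the effect, a lower number that less compound is needed), three compounds have been tested: compound 1 (`COC(=O)c1c(-c2cc(OC)cc(OC)c2)oc2ccccc2c1=O`), compound 2 (`COC(=O)c1c(-c2ccc(Br)cc2)oc2ccccc2c1=O`) and compound 3 (`COC(=O)c1c(-c2ccc([N+](=O)[O-])cc2)oc2cc(OC)ccc2c1=O`). Compound 1 reads > 25 ug/mL as a limit, not a number. Compound 2 reads > 25 ug/mL and that too is only a limit. Compound 3 reads > 25 ug/mL as a limit as well. Compound 2 therefore has no number of its own, and the other two offer none to place it against, since the whole set sits at one mark (the limit of > 25 ug/mL in this assay, at which 3 of the 3 values shown sit).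

The next compound, compound 4 (`COC(=O)c1c(-c2ccc(N)cc2)oc2ccccc2c1=O`), differs from compound 2 in one place (amino in place of bromo on an aromatic carbon). It carries amino in place of bromo on an aromatic carbon, para to a large group. Going by the values given here, no two measured compounds differ in just one place, so this assay offers no measured step by which to size this change. No step beyond the usual scatter is expected, and another limit is quite likely. The expectation rests on compound 2, whose reading of > 25 ug/mL is a limit. The estimated a number no higher from compound 2 to compound 4 (the limit leaves the size open) reflects that expectation. For compound 4 the expected concentration for half-maximal effect is 25 ug/mL within an estimated range (10 ug/mL to 50 ug/mL).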

Compound 4, concentration for half-maximal effect: > 25 ug/mL
Compound 4 was reported as a limit (the forecaster's own chance of this, stated with the estimate: 65%); the middle value sits exactly at the limit.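

No step can be read between compound 2 and compound 4 in this assay, since both give only a limit, and the whole set now sits at one mark: the limit of > 25 ug/mL in this assay, at which 4 of the 4 values shown sit. The compounds shown leave open whether any change on the shared core gives a measured number, and so how amino and bromo compare.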